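Halogen swap carried from one core to the other

This account rests on a few compounds, and the source may have more. Where it says the series, first, only, none or still open, it means among the compounds named here.

Compound 1 `CN1C(=O)C2(C(C#N)=C(N)Oc3cc4oc(-c5ccccc5)cc(=O)c4c(O)c32)c2cc(Cl)ccc21` and compound 2 `CN1C(=O)C2(C(C#N)=C(N)Oc3cc4oc(-c5ccccc5)cc(=O)c4c(O)c32)c2cc(Br)ccc21` share one core; compound 3 `N#CC1=C(N)Oc2cc3oc(-c4ccccc4)cc(=O)c3c(O)c2C12C(=O)Nc1cc(Cl)ccc12` and compound 4 `N#CC1=C(N)Oc2cc3oc(-c4ccccc4)cc(=O)c3c(O)c2C12C(=O)Nc1cc(Br)ccc12` share another. The difference between the two cores is not broken down here.

In a functional assay on K562 cells (Homo sapiens) for antiproliferative activity, read by MTT assay, with a stated time of 48 h (on this read-out lower numbers stand for stronger inhibition and higher numbers for weaker inhibition), compound 1 gives 4340 nM. Compound 2 gives 4100 nM in this assay. The change that separates them, (bromo in place of chloro on an aromatic carbon), made a 1.1-fold lower number from compound 1 to compound 2 (0.02 log units; within the scatter), so the two numbers cannot be told apart. For the measured compounds named here, compound 3 gives 9250 nM in this assay, the highest number of the three measured, and its gap to both compound 1 and compound 2 lies beyond the scatter; no single-point step to either is counted, since the cores differ.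

Compound 4 has not been measured. It differs from compound 3 by bromo in place of chloro on an aromatic carbon, and the place is described in the same words as for the change from compound 1 to compound 2, so this is the same change. Going by the values given here, the only precedent for it is a step that did not move the number. The expected step is a 1.1-fold lower number from compound 3 to compound 4 (0.03 log units; within the scatter) because the same change gave a 1.1-fold lower number from compound 1 to compound 2 (0.02 log units; within the scatter) in the other core. Compound 4 is therefore expected to give about 8700 nM in this assay. Among the compounds with values here, the estimate for compound 4 is bounded at the low end by 4500 nM and at the high end by 17000 nM, the width reflecting that only one precedent exists and that it sits in a different core.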

Compound 4, half-maximal inhibitory concentration: 8700 nM
Estimate against measurement, compound 4: no gap at the digits printed; the measured number falls inside the stated range.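

In this assay, bromo in place of chloro on an aromatic carbon gave a 1.1-fold lower number from compound 3 to compound 4 (0.03 log units; within the scatter), so the swap leaves the number unresolved from the scatter on the core of compound 3, as it does on the core of compound 1. Set side by side, the two steps agree, and this halogen swap carries from one core to the other in this series: the same change on two cores in this assay, a 1.1-fold lower number (0.02 log units; within the scatter) from compound 1 to compound 2 and a 1.1-fold lower number (0.03 log units; within the scatter) from compound 3 to compound 4, 1.0-fold (0.00 log units) apart, within the scatter of two such steps. This agreement rests on a single pair of halogens on two cores and consists of two steps that did not move the number, so it shows no transfer of a measurable shift, and it says nothing about any third core, any other change, or any read-out besides this one.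

The compounds shown leave open whether anything other than chloro or bromo at this aromatic carbon would move the number, for instance fluoro, methoxy, an amine or a carboxylic acid. They also leave open whether a change elsewhere on the two cores, such as a substituted phenyl or an amide in place of the nitrile, would carry between them as faithfully as this swap did.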